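Swapping Bromo for Methoxy on the Carbonyl-Bearing Ring

A few compounds are considered here, and "the series" means these few. Any claim that something is new, unique, unknown or untested is made for them only; others in the source may bear on it.

Three chalcone-type compounds share one core and differ only in a single group on the aromatic ring that carries the carbonyl. Compound 1 `CCCC(C)Oc1ccc(C(=O)/C=C/c2c(/C=C/c3ccc(OC)cc3)cc(OC)cc2OC)cc1` bears a 1-methylbutoxy group there; in a functional assay on B16-F10 cells (Mus musculus) for antiproliferative activity, read by MTT assay, with a stated time of 48 h (a lower number here means a stronger inhibitor, a higher number a weaker inhibitor), compound 1 gives 6.7 ug/mL. Compound 2 `COc1ccc(/C=C/c2cc(OC)cc(OC)c2/C=C/C(=O)c2ccc(C)cc2)cc1` carries a methyl in that place, and in this assay compound 2 gives 5.3 ug/mL. Compound 3 `COc1ccc(/C=C/c2cc(OC)cc(OC)c2/C=C/C(=O)c2ccc(Br)cc2)cc1` carries a bromo, and in this assay compound 3 gives 6.5 ug/mL, the second highest of the three numbers, though every gap between these compounds is within the scatter: a 1.3-fold lower number from compound 1 to compound 2 (0.10 log units; within the scatter), a 1.0-fold lower number from compound 1 to compound 3 (0.01 log units; within the scatter) and a 1.2-fold higher number from compound 2 to compound 3 (0.09 log units; within the scatter).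

Compound 4 `COc1ccc(/C=C/c2cc(OC)cc(OC)c2/C=C/C(=O)c2ccc(OC)cc2)cc1` is the next variation: methoxy in place of bromo on an aromatic carbon. The most telling comparison is the step from an alkoxy group to bromo, a 1.0-fold lower number from compound 1 to compound 3 (0.01 log units; within the scatter), which left the number essentially where it was; the step from methyl to bromo, a 1.2-fold higher number from compound 2 to compound 3 (0.09 log units; within the scatter), was equally small. Since three quite different groups at this position all land within the scatter of one another, the return to an alkoxy group in compound 4 is expected to change little in this assay, with a step of a 1.1-fold lower number from compound 3 to compound 4 (0.03 log units; within the scatter) anticipated. Compound 4 is therefore estimated at 6 ug/mL, with a likely range from 3 ug/mL to 12 ug/mL.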

Compound 4, half-maximal inhibitory concentration: 5.8 ug/mL
Beside the measured number, compound 4's estimate is 1.0-fold (0.01 log units) above it, and the stated range covers the measured number.
By their numbers in this assay, from the lowest: compounds 2, 4, 3 and 1 (each within the scatter of the next).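

Methoxy is a fourth group at this place on the ring that carries the carbonyl, and in this assay it stays within the scatter of all three groups before it: the steps are small against bromo (a 1.1-fold lower number from compound 3 to compound 4 (0.05 log units; within the scatter)) and against methyl (a 1.1-fold higher number from compound 2 to compound 4 (0.04 log units; within the scatter)). The earlier compounds held only one group joined through oxygen, so they could not show what the size of the chain on that oxygen does; the step that cuts 1-methylbutyl down to methyl (a 1.2-fold lower number from compound 1 to compound 4 (0.06 log units; within the scatter)) also stays within the scatter, so among these four compounds neither the change of atom at the ring nor the length of that chain separates the numbers. No measurement is available that would explain why the numbers at this position stay so close together.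

From the compounds shown here alone, all four groups sit at the same place on the same ring, so it remains open whether an amine, a carboxylic acid or a much longer chain there would move the number beyond the scatter. Also open, going by these compounds, is whether these groups would stay as close together at another carbon of that ring, or on cells other than the ones tested here.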